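From compound 3 to compound 4: methyl to chloro

The source may report more compounds than this note shows. Statements on the series, on what has been measured and on what is new or still open speak of the compounds shown alone.

In a functional assay on MCF7 cells (Homo sapiens) for antiproliferative activity, read by MTT assay, with a stated time of 72 h (a higher number here means a weaker inhibitor, a lower number a stronger inhibitor), compound 3 (`CC1=CC[C@H]2[C@H](CC[C@]2(C)O)C(C)(C)[C@@H]1CC[C@H]1[C@]2(C)CC[C@H](OC(=O)c3ccc(C)cc3)C(C)(C)O[C@H]2CC[C@@]1(C)O`) gives > 50000 nM, which is a limit and not a number. Compound 1 (`CC1=CC[C@H]2[C@H](CC[C@]2(C)O)C(C)(C)[C@@H]1CC[C@H]1[C@]2(C)CC[C@H](OC(=O)CCC(=O)O)C(C)(C)O[C@H]2CC[C@@]1(C)O`) gives > 50000 nM, also a limit. Compound 2 (`CC1=CC[C@H]2[C@H](CC[C@]2(C)O)C(C)(C)[C@@H]1CC[C@H]1[C@]2(C)CC[C@H](OC(=O)c3ccncc3)C(C)(C)O[C@H]2CC[C@@]1(C)O`) gives a number, 25300 nM.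

Compound 4 (`CC1=CC[C@H]2[C@H](CC[C@]2(C)O)C(C)(C)[C@@H]1CC[C@H]1[C@]2(C)CC[C@H](OC(=O)c3ccc(Cl)cc3)C(C)(C)O[C@H]2CC[C@@]1(C)O`) carries chloro in place of methyl on an aromatic carbon, chloro in place of methyl on an aromatic carbon. Within the data shown here, no measured step covers this exchange. The nearest steps change the group on the carbonyl carbon: an at least 1.9-fold higher number from compound 2 to compound 3 (0.29 log units; that floor lies within the scatter), and an at least 1.9-fold lower number from compound 1 to compound 2 (0.29 log units; that floor lies within the scatter). Both floors lie within the scatter. Among the measured compounds shown here, the series so far shows (the limit of > 50000 nM in this assay, at which 2 of the 3 values shown sit).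

The expected result is no change beyond the scatter, with the estimated step being an at least 1.1-fold lower number from compound 3 to compound 4 (0.04 log units; that floor lies within the scatter). The estimate for compound 4 is 45000 nM, with an expected range of 20000 nM to 80000 nM.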

Compound 4, half-maximal inhibitory concentration: 24100 nM
Estimate against measurement, compound 4: 1.9-fold (0.27 log units) above; low and high end bracket the measured number.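

In this assay, chloro in place of methyl, para to a large group, brings the aryl series off its limit, with an at least 2.0-fold lower number from compound 3 to compound 4 (0.31 log units; beyond the scatter). The 4-chlorophenyl group also separates from 2-carboxyethyl, with an at least 2.0-fold lower number from compound 1 to compound 4 (0.31 log units; beyond the scatter), while it does not separate from pyridin-4-yl, with a 1.0-fold lower number from compound 2 to compound 4 (0.02 log units; within the scatter). The two steps beyond the scatter are floors and not sizes: the limit of > 50000 nM in this assay, at which 2 of the 4 values shown sit.

On these data alone, how bromo, methoxy or an amine would read at this place stays open. As far as these compounds go, the true distance between compound 3 and compound 4 also stays open.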